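From Ethyl to Acetyl on a Shared Core

The source may report more compounds than this note shows. Statements on the series, on what has been measured and on what is new or still open speak of the compounds shown alone.

Compound 3 `CCc1ccc2oc(N3CCN(C)CC3)nc2c1` carries an ethyl on an aromatic carbon of the shared core. In a functional assay on ileum (strain Hartley) for agonist activity at 5-hydroxytryptamine receptor 3A (Cavia porcellus) (a higher number here means a more potent compound, by a factor of ten per unit of this negative logarithm, a lower number a less potent compound), compound 3 gives only a limit, < 4, and no number. Compound 1 `CN1CCN(c2nc3cc(C(F)(F)F)ccc3o2)CC1`, with trifluoromethyl at the same place, also gives only the limit < 4. Compound 2 `CN1CCN(c2nc3cc(F)ccc3o2)CC1`, with fluoro there, gives 5.57 in this assay. Two of the three values sit at the limit (the limit of < 4 in this assay, at which 2 of the 3 values shown sit), and compound 3 is one of them, with a step of a number at least 1.57 log units lower from compound 2 to compound 3 (beyond the scatter) and a step that the two limits leave unreadable from compound 1 to compound 3. Compound 4 `CC(=O)c1ccc2oc(N3CCN(C)CC3)nc2c1` replaces the ethyl with an acetyl: acetyl in place of ethyl on an aromatic carbon. Going by the values given here, none of the measured steps involves an acetyl or a carbonyl, and the steps of a number at least 1.57 log units higher from compound 1 to compound 2 (beyond the scatter) and a number at least 1.57 log units lower from compound 2 to compound 3 (beyond the scatter) show only that fluoro stands well above both ethyl and trifluoromethyl. Compound 4 is expected to stay near the limit, with an estimated step of a number at least 0.30 log units higher from compound 3 to compound 4 (that floor lies within the scatter). The estimated value for compound 4 in this assay is 4.3, between 3.5 and 5.2.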

Compound 4, negative logarithm of the half-maximal effective concentration: < 4
Compound 4: a limit, no number (the forecaster's own chance of this, stated with the estimate: 50%); middle value at least 0.30 log units from the limit.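

In this assay compound 4 gives < 4, which is a limit of the assay and not a number. So a group carrying a carbonyl on this aromatic carbon joins ethyl and trifluoromethyl at the limit, leaving fluoro as the only group shown here that gives a number, and the change from fluoro to acetyl is a number at least 1.57 log units lower from compound 2 to compound 4 (beyond the scatter). The steps from compound 3 to compound 4 and from compound 1 to compound 4 cannot be read, because both ends of each are limits: the limit of < 4 in this assay, at which 3 of the 4 values shown sit.

Going by these compounds, how far compound 1, compound 3 and compound 4 differ from one another stays open. Also open, on these data alone, is whether a chloro, a methoxy or an amine on this same carbon would give a number in this assay, as fluoro does.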